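A few compounds are considered here, and "the series" means these few. Any claim that something is new, unique, unknown or untested is made for them only; others in the source may bear on it.

Compound 1 `Cc1cc(N)ccc1-c1nc2ccccc2s1`: < 0.1 nM; < 0.1 nM (2 entries) (a limit)
Compound 2 `CCc1cc(N)ccc1-c1nc2ccccc2s1`: < 0.1 nM (a limit)
Compound 3 `Nc1ccc(-c2nc3ccccc3s2)c(Cl)c1`: < 0.1 nM (a limit)

In a functional assay on MCF7 cells (Homo sapiens) for inhibition (a higher number here means a weaker inhibitor, a lower number a stronger inhibitor), compound 3 gives < 0.1 nM, which is a limit of the assay and not a number. Compound 4 `N#Cc1cc(N)ccc1-c1nc2ccccc2s1` carries cyano in place of chloro on an aromatic carbon. Going by the values given here, the one measured step that bears on this change is a step that the two limits leave unreadable from compound 2 to compound 3, and it has no readable size. Among the compounds with values here, with the limit of < 0.1 nM in this assay, at which 2 of the 3 values shown sit, as the only evidence, no step beyond the usual scatter is expected in either direction, although a weaker result cannot be ruled out. The expected change is a number no lower from compound 3 to compound 4 (the limit leaves the size open). For compound 4 the estimate is 0.1 nM, with an expected range from 0.02 nM to 2 nM.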

Compound 4, half-maximal inhibitory concentration: < 10 nM
Compound 4: only a limit was reported (the forecaster's own chance of this, stated with the estimate: 60%); the middle value lies beyond the limit too.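

Compound 4 is reported only as a limit, < 10 nM, and compound 2 and compound 3 are limits too, so the steps among them cannot be read. On these data alone, whether cyano, chloro and ethyl differ at all in this assay stays open.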